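The compounds below may be only part of what the source reports. "The series", "measured", "known", "first", "only" and "open" are said of these compounds alone.

Measured compounds in a functional assay on PC-3 cells (Homo sapiens) for inhibition, read by MTT assay, with a stated time of 72 h; a lower number here means a stronger inhibitor, a higher number a weaker inhibitor:
- compound 1 `C#CCSc1nc(Nc2ccccc2)c2ccncc2n1`: > 80000 nM
- compound 2 `C#CCSc1nc(Nc2ccc(Br)cc2)c2ccncc2n1`: 26000 nM
- compound 3 `C#CCSc1nc(Nc2ccc([N+](=O)[O-])cc2)c2ccncc2n1`: > 80000 nM

In this assay compound 3 gives only a limit of the assay, > 80000 nM, not a number. Compound 1 likewise sits at a limit, > 80000 nM. Two of the three values therefore stand at the limit of > 80000 nM in this assay, at which 2 of the 3 values shown sit, and only compound 2, with 26000 nM, gives a readable number. The measured steps are an at least 3.0-fold lower number from compound 1 to compound 2 (0.48 log units; beyond the scatter), an at least 3.0-fold higher number from compound 2 to compound 3 (0.48 log units; beyond the scatter) and a step that the two limits leave unreadable from compound 1 to compound 3.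

Compound 4 `C#CCSc1nc(Nc2ccc(O)cc2)c2ccncc2n1` differs from compound 3 by hydroxy in place of nitro on an aromatic carbon. Among the measured compounds shown here, none of the measured steps involves a hydroxy group, so they bear on this change only indirectly: the two substituent changes read so far show that a substituent at this position can move the number in either direction, bromo giving a number and nitro giving a limit. With two of three values at the limit, the most likely outcome for compound 4 is again a weak or unreadable result, with a modest chance of a number of the order seen for compound 2.

Compound 4 is therefore estimated at 60000 nM in this assay, in a range from 15000 nM to 80000 nM. The expected step is an at least 1.3-fold lower number from compound 3 to compound 4 (0.12 log units; that floor lies within the scatter), which cannot be read against a starting limit.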

Compound 4, half-maximal inhibitory concentration: > 80000 nM
Compound 4: no number, only a limit; the forecaster's own chance of this, stated with the estimate: 55%; middle value at least 1.3-fold (0.12 log units) away from the limit.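

In this assay compound 4 gives > 80000 nM, which is a limit of the assay and not a number. Hydroxy in place of bromo on this aromatic carbon, para to a large group, gives an at least 3.0-fold higher number from compound 2 to compound 4 (0.48 log units; beyond the scatter), so bromo is now the only one of the four substituents shown that gives a readable number, and neither of the two oxygen-bearing groups, hydroxy and nitro, does. The steps among compound 1, compound 3 and compound 4 cannot be read, as both ends of each are limits, and the series now rests largely on a single readable value: the limit of > 80000 nM in this assay, at which 3 of the 4 values shown sit.

From the compounds shown here alone, whether hydrogen, nitro and hydroxy differ from one another at all remains open, since any such difference lies beyond the reach of this assay's limit. Also open, going by these compounds, is whether the number for compound 2 is particular to bromo or would extend to a chloro or iodo atom, and what an amine, a methoxy group or a carboxylic acid would give at this place.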